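Replacing the oxane-methyl amine substituent with a dimethylcyclohexyl group

The source may hold more compounds than are shown below. What is called first, only, known or untested is meant among the compounds shown, and "the series" means these compounds.

Measured compounds:
- compound 1 `c1ccc(CNCCCCN(C[C@H]2Cc3ccccc3CN2)[C@H]2CCCc3cccnc32)cc1`: 20.1 nM
- compound 2 `c1ccc2c(c1)CN[C@@H](CN(CCCCNCC1CCSCC1)[C@H]1CCCc3cccnc31)C2`: 69.6 nM
- compound 3 `C(=C/CN(C[C@H]1Cc2ccccc2CN1)[C@H]1CCCc2cccnc21)\CNCC1CCOCC1`: 24.2 nM

In a functional assay on cells for antagonist activity at C-X-C chemokine receptor type 4 (Homo sapiens), read by fluorescence and calcium flux, with stated times of 25 min and 90 s (a higher number here means a weaker inhibitor, a lower number a stronger inhibitor), compound 3 gives 24.2 nM, the second highest of the three numbers. Its nearest neighbour is compound 1 at 20.1 nM, a difference within the scatter; compound 2 at 69.6 nM is furthest, and the step of a 2.9-fold lower number from compound 2 to compound 3 (0.46 log units; beyond the scatter) is beyond the scatter.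

Compound 4 `CC1(C)CCC(NC/C=C/CN(C[C@H]2Cc3ccccc3CN2)[C@H]2CCCc3cccnc32)CC1` differs from compound 3 in one place: 4,4-dimethylcyclohexyl in place of (oxan-4-yl)methyl on an amine nitrogen. The change in the same region is what the measured steps probe. The step of a 1.2-fold higher number from compound 1 to compound 3 (0.08 log units; within the scatter) was within the scatter, while a 3.5-fold higher number from compound 1 to compound 2 (0.54 log units; beyond the scatter) and a 2.9-fold lower number from compound 2 to compound 3 (0.46 log units; beyond the scatter) were modest. Varying the ring on this amine thus moved the number by small amounts in both directions, and the present change again keeps a six-membered non-aromatic ring there, but one of carbon only and bound directly to the nitrogen. A step of about the size seen in the measured pairs is therefore expected, with no firm direction.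

For compound 4 the estimate in this assay is 32 nM, with a range of 12 nM to 85 nM, which is expected to amount to a 1.3-fold higher number from compound 3 to compound 4 (0.12 log units; within the scatter).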

Compound 4, half-maximal inhibitory concentration: 64.6 nM
Compound 4: middle estimate off by 2.0-fold (0.31 log units), on the low side; the measured number falls inside the stated range.
By their numbers in this assay, from the lowest: compounds 1 and 3 (each within the scatter of the next); then compounds 4 and 2 (each within the scatter of the next).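

In this assay, the step of a 2.7-fold higher number from compound 3 to compound 4 (0.43 log units; beyond the scatter) is beyond the scatter, so this amine substituent is not freely interchangeable, even though the earlier change from the phenyl-bearing compound 1 to the oxane-bearing compound 3 stayed within the scatter. Compound 4 is the only compound shown whose ring is bound directly to the amine nitrogen rather than through a saturated chain carbon, and retaining a six-membered non-aromatic ring at this position did not keep the number at the level of compound 3 at 24.2 nM. The step remains modest, and no measurement shown gives a cause for it.

Going by these compounds, this single change removes the ring oxygen, removes the chain carbon linking ring to nitrogen and adds the dimethyl substitution, so the share of each in the step stays open. Oxan-4-yl bound directly to the amine nitrogen, cyclohexyl at the same place and (4,4-dimethylcyclohexyl)methyl would each separate these parts, with the rest of the structure of compound 3 held constant.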